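Amide for amine on the pyridine: lipophilicity notes

This account rests on a few compounds, and the source may have more. Where it says the series, first, only, none or still open, it means among the compounds named here.

Measured so far in a physicochemical assay for lipophilicity, using the shake flask method, in phosphate buffer, measured as octanol-water partition, with a stated time of 30 min, at pH 7.4; on this read-out higher numbers stand for higher lipophilicity and lower numbers for lower lipophilicity
compound 1 `Cn1cc(-c2cnc(NCc3c(F)ccc4c3CCO4)c3cn[nH]c(=O)c23)cn1` gives 2.7
compound 2 `Cc1ncc(-c2cnc(NCc3c(F)ccc4c3CCO4)c3cn[nH]c(=O)c23)n1C` gives 1.9
compound 3 `Cc1nc(CN(C)C)ccc1-c1cnc(NCc2c(F)ccc3c2CCO3)c2cn[nH]c(=O)c12` gives 2

Compound 3 sits level with compound 2 within the scatter and clearly under compound 1. Compound 4 `CNC(=O)c1ccc(-c2cnc(NCc3c(F)ccc4c3CCO4)c3cn[nH]c(=O)c23)c(C)n1` differs from compound 3 by methylcarbamoyl in place of (dimethylamino)methyl on an aromatic carbon and so has methylcarbamoyl in place of (dimethylamino)methyl on an aromatic carbon next to the ring nitrogen.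

Within the data shown here, no measured step makes this exchange alone. The nearest evidence comes from swaps of the whole aromatic substituent: a number 0.70 log units lower from compound 1 to compound 3 (beyond the scatter) is modest, a number 0.80 log units lower from compound 1 to compound 2 (beyond the scatter) is similar in size, and a number 0.10 log units higher from compound 2 to compound 3 (within the scatter) stays within the scatter. A modest step in this assay is therefore expected, not a large one. With compound 3 at 2 near the low end of the measured range, a rise is judged likelier than a fall, though this is weakly supported.

The expected change is a number 0.40 log units higher from compound 3 to compound 4 (beyond the scatter) in this estimate. For compound 4 the estimated value is 2.4 with an expected range of 1.9 to 2.9 in this assay.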

Compound 4, distribution coefficient: 2.9
Estimate against measurement, compound 4: 0.50 log units below; the range from low to high includes it.
By their numbers in this assay, from the lowest: compounds 2 and 3 (each within the scatter of the next); then compounds 1 and 4 (each within the scatter of the next).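

In this assay, the exchange of (dimethylamino)methyl for methylcarbamoyl on the aromatic carbon next to the ring nitrogen can now be read alone: a number 0.90 log units higher from compound 3 to compound 4 (beyond the scatter). A change confined to this one group therefore separates two compounds that share the rest of the pyridine substituent, and a number 1.00 log units higher from compound 2 to compound 4 (beyond the scatter), whereas a number 0.20 log units higher from compound 1 to compound 4 (within the scatter), which leaves 2-methyl-6-(methylcarbamoyl)pyridin-3-yl and 1-methyl-1H-pyrazol-4-yl level on this read-out. Nothing available here explains the size or direction of the step.

From the compounds shown here alone, it remains open which part of methylcarbamoyl goes with the step, the carbonyl or the amide hydrogen. A dimethylcarbamoyl group, a primary carboxamide or a carboxylic acid on this aromatic carbon would test that, and the compounds shown cannot say whether the step carries over to other cores.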